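This account rests on a few compounds, and the source may have more. Where it says the series, first, only, none or still open, it means among the compounds named here.

Measured so far in a functional assay on HOP-62 cells (Homo sapiens) for inhibition; on this read-out lower numbers stand for stronger inhibition of growth and higher numbers for weaker inhibition of growth:
- compound 1 `O=C(/C=C/c1cccc(O)c1)c1cccc(-n2cc(-c3ccccc3)[nH]c2=O)c1`: 6930 nM
- compound 2 `O=C(/C=C/c1cccc(O)c1)c1cccc(-n2cc(-c3ccc(Cl)cc3)[nH]c2=O)c1`: 2360 nM

Compound 2 holds the lower of the two numbers, at 2360 nM, so it is the stronger inhibitor of growth in this small set. Among the measured compounds shown here, the only measured step, a 2.9-fold lower number from compound 1 to compound 2 (0.47 log units; beyond the scatter), is chloro in place of hydrogen on an aromatic carbon.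

Compound 3 `COc1cc(/C=C/C(=O)c2cccc(-n3cc(-c4ccc(Cl)cc4)[nH]c3=O)c2)ccc1O` keeps that chloro and carries a different change: 4-hydroxy-3-methoxyphenyl in place of 3-hydroxyphenyl on a double-bonded chain carbon bound to a double-bonded chain carbon. In words, 4-hydroxy-3-methoxyphenyl stands in place of 3-hydroxyphenyl on a double-bonded chain carbon bound to a double-bonded chain carbon.

For the measured compounds named here, no measured step covers this exchange. The step of a 2.9-fold lower number from compound 1 to compound 2 (0.47 log units; beyond the scatter) is a different change at a different place, so it gives only a rough size for one change in this series and no direction. With no direction supported by the data, no shift beyond the scatter is expected in this assay.

The expected step is a 1.1-fold lower number from compound 2 to compound 3 (0.03 log units; within the scatter).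

For compound 3 the estimated value is 2200 nM, with an expected range from 750 nM to 6500 nM.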

Compound 3, concentration for 50% growth inhibition: 2840 nM
For compound 3 the middle estimate is 1.3-fold (0.11 log units) below the measured one, within the range that was stated.
By their numbers in this assay, from the lowest: compounds 2 and 3 (each within the scatter of the next); then compound 1.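

In this assay, among the compounds shown here, the exchange of 3-hydroxyphenyl for 4-hydroxy-3-methoxyphenyl on a double-bonded chain carbon bound to a double-bonded chain carbon gives a 1.2-fold higher number from compound 2 to compound 3 (0.08 log units; within the scatter) and is the first measured step at this place. For the compounds shown here, with the chloro kept, this exchange therefore leaves the number within the scatter, whereas the only earlier step, a 2.9-fold lower number from compound 1 to compound 2 (0.47 log units; beyond the scatter), lies at a different place and beyond the scatter. No evidence on the cause of this result is at hand.

Going by these compounds alone, the single step does not separate the methoxy group from the different placement of the hydroxy group, since both change together in this exchange, and it is tested only with the chloro present. Also open, from the compounds shown here alone, is whether an aminophenyl or carboxyphenyl group at this place, or an ethoxy group in place of the methoxy, would stay within the scatter or give a step beyond it.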